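This account rests on a few compounds, and the source may have more. Where it says the series, first, only, none or still open, it means among the compounds named here.

In a physicochemical assay for solubility (on this read-out higher numbers stand for higher solubility and lower numbers for lower solubility), compound 1 `O=S(=O)(Nc1ncccn1)c1ccc2c(c1)CC[C@@H]2c1ccc(C(F)(F)F)cc1-c1ccc(F)nc1` reads 40000 nM and compound 2 `Cn1nccc1-c1cc(C(F)(F)F)ccc1[C@H]1CCc2cc(S(=O)(=O)Nc3ncccn3)ccc21` reads 316000 nM as the higher of the two numbers. Compound 3 `Cc1ccc(-c2cc(C(F)(F)F)ccc2[C@H]2CCc3cc(S(=O)(=O)Nc4ncccn4)ccc32)cn1` has not yet been measured. It differs from compound 2 by 6-methylpyridin-3-yl in place of 1-methyl-1H-pyrazol-5-yl on an aromatic carbon with 6-methylpyridin-3-yl in place of 1-methyl-1H-pyrazol-5-yl on an aromatic carbon, ortho to a large group and meta to a trifluoromethyl group. For the measured compounds named here, only one measured step bears on this change. That step is a 7.9-fold higher number from compound 1 to compound 2 (0.90 log units; beyond the scatter) and it put 1-methyl-1H-pyrazol-5-yl in place of 6-fluoropyridin-3-yl at the same carbon. Compound 3 gives up that same group and carries 6-methylpyridin-3-yl where compound 1 carries 6-fluoropyridin-3-yl. A fall in this assay beyond the scatter is therefore expected, similar in size to the measured step but probably somewhat smaller. Going by the values given here, no measurement yet compares the two pyridinyl groups directly, so the range stays wide. The estimated change is a 4.5-fold lower number from compound 2 to compound 3 (0.65 log units; beyond the scatter) for this pair. Compound 3 is expected at 70000 nM with an estimated range from 25000 nM to 200000 nM.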

Compound 3, solubility: 47000 nM
For compound 3 the middle estimate is 1.5-fold (0.17 log units) above the measured one, and the stated range covers the measured number.
By their numbers in this assay, from the lowest: compounds 1 and 3 (each within the scatter of the next); then compound 2.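

In this assay, moving from 1-methyl-1H-pyrazol-5-yl to a second pyridinyl group gives a 6.7-fold lower number from compound 2 to compound 3 (0.83 log units; beyond the scatter), so the gap first seen with 6-fluoropyridin-3-yl also appears with 6-methylpyridin-3-yl. The two pyridinyl groups differ by methyl in place of fluoro, and this change gives a 1.2-fold higher number from compound 1 to compound 3 (0.07 log units; within the scatter), which lies within the scatter, so this read-out does not separate them at this position and compound 2 alone stands apart among the three compounds. Nothing at hand gives a measured reason for either step.

The compounds shown leave open whether the higher number of compound 2 belongs to the pyrazolyl group in particular or extends to other five-membered aromatic rings, such as an imidazolyl or a thiazolyl group, and whether the methyl on the pyrazolyl nitrogen plays any part in it. They also leave open whether a different substituent at the same pyridinyl carbon, such as a dimethylamino group or a carboxylic acid, would move the number away from that of the methyl and fluoro pair.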